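Moving the Thiophene Attachment Point on a Chain Carbon

The compounds below may be only part of what the source reports. "The series", "measured", "known", "first", "only" and "open" are said of these compounds alone.

Cell-toxicity tests show how much of a compound it takes to harm cells, and this small series has been measured in an ADME assay on HeLa cells (Homo sapiens) for cytotoxicity, read by resazurin assay, with a stated time of 2 days; a lower number here means a stronger inhibitor, a higher number a weaker inhibitor. All the compounds share one core and differ in the ring on a double-bonded chain carbon. Compound 1 `Cn1c([N+](=O)[O-])cnc1/C=C/c1ccccc1Cl` gives > 100000 nM, which is a limit of the assay and not a number.

For the measured compounds named here, only two compounds so far have true numbers: compound 2 `Cn1c([N+](=O)[O-])cnc1/C=C/c1ccco1` gives 93300 nM and compound 3 `Cn1c([N+](=O)[O-])cnc1/C=C/c1cccs1` gives 91200 nM. Compound 3 therefore stands level with compound 2, within the scatter of repeated measurements.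

The next compound, compound 4 `Cn1c([N+](=O)[O-])cnc1/C=C/c1ccsc1`, has the same atoms as compound 3, joined differently: thiophen-3-yl in place of thiophen-2-yl on a double-bonded chain carbon bound to a double-bonded chain carbon. The ring stays a thiophene, and only its point of attachment to the chain changes, with thiophen-3-yl in place of thiophen-2-yl.

Going by the values given here, one measured step bears on this place, the exchange of furan-2-yl for thiophen-2-yl, which gave a 1.0-fold lower number from compound 2 to compound 3 (0.01 log units; within the scatter). Even that change of ring left the number unmoved, so a shift in attachment point is expected to leave this assay much the same. The expected result is a 1.0-fold lower number from compound 3 to compound 4 (0.01 log units; within the scatter), which means no step beyond the scatter. For compound 4 the estimated value is 90000 nM, with an expected range from 50000 nM to 140000 nM.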

Compound 4, half-maximal inhibitory concentration: > 100000 nM
Compound 4 gave a limit, no number (the forecaster's own chance of this, stated with the estimate: 30%); middle value at least 1.1-fold (0.04 log units) away from the limit.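

In this assay the result for compound 4 is a limit and not a number, so this position, on a double-bonded chain carbon, now holds one thiophene with a true number and one with only a limit. On these data alone, the steps can be read only as floors, an at least 1.0-fold higher number from compound 3 to compound 4 (0.04 log units; that floor lies within the scatter) and an at least 1.0-fold higher number from compound 2 to compound 4 (0.03 log units; that floor lies within the scatter) and neither floor lies beyond the scatter, so the true size of moving the attachment point remains unknown and could be small or large. For the compounds shown here, what the earlier compounds did not show is that thiophen-3-yl brings a second compound, alongside compound 1, to the top of what this test can report, which restricts what the series can say about very weak cell toxicity: the limit of > 100000 nM in this assay, at which 2 of the 4 values shown sit.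

The compounds shown leave open whether attachment point matters for other rings, as furan-3-yl would show when set against the furan-2-yl of compound 2. They also leave open whether an amine or a carboxylic acid on the thiophene, or a longer chain leading to it, would bring the number clearly down from this limit.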